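Swapping the anilino ring: from compound 3 to compound 4

This account rests on a few compounds, and the source may have more. Where it says the series, first, only, none or still open, it means among the compounds named here.

Of the compounds shown here, three sharing one core have been tested in a functional assay on U-87MG ATCC cells for antiproliferative activity against U-87 MG (Homo sapiens), read by spectrophotometry, with a stated time of 2 days; a higher number here means a weaker inhibitor of growth, a lower number a stronger inhibitor of growth. Compound 1 `COc1cc(Nc2ncc(C(F)(F)F)c(N3Cc4cccc(N(C)S(C)(=O)=O)c4C3)n2)cc(OC)c1` reaches only the limit of the measurement, > 30000 nM. Compound 2 `Cc1ccc(Nc2ncc(C(F)(F)F)c(N3Cc4cccc(N(C)S(C)(=O)=O)c4C3)n2)c(Cl)c1` likewise stops at the limit, > 30000 nM. Going by the values given here, compound 3 `COc1cc(Nc2ncc(C(F)(F)F)c(N3Cc4cccc(N(C)S(C)(=O)=O)c4C3)n2)c(OC)cc1Cl` is the single compound with a real number, giving 6200 nM in this assay, and so it stands as the only reference point. The steps to it are readable in one direction only: an at least 4.8-fold lower number from compound 1 to compound 3 (0.68 log units; beyond the scatter) and an at least 4.8-fold lower number from compound 2 to compound 3 (0.68 log units; beyond the scatter), while a step that the two limits leave unreadable from compound 1 to compound 2, because of the limit of > 30000 nM in this assay, at which 2 of the 3 values shown sit.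

Compound 4 `COc1cc(Nc2ncc(C(F)(F)F)c(N3Cc4cccc(N(C)S(C)(=O)=O)c4C3)n2)cc(C(F)(F)F)c1` differs from compound 3 in that anilino ring alone: 3-methoxy-5-(trifluoromethyl)phenyl in place of 4-chloro-2,5-dimethoxyphenyl on a nitrogen on an aromatic ring. The new ring keeps one methoxy and resembles the ring of compound 1 more than that of compound 3, and compound 1 sat at the limit > 30000 nM. A weakening is therefore expected, a 3.2-fold higher number from compound 3 to compound 4 (0.51 log units; beyond the scatter), quite possibly back to the limit. Compound 4 is estimated at 20000 nM, within 6000 nM to 60000 nM.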

Compound 4, concentration for 50% growth inhibition: > 30000 nM
Compound 4 ended at the assay's limit (the forecaster's own chance of this, stated with the estimate: 45%); at least 1.5-fold (0.17 log units) between middle value and limit.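

In this assay, replacing 4-chloro-2,5-dimethoxyphenyl with 3-methoxy-5-(trifluoromethyl)phenyl gives an at least 4.8-fold higher number from compound 3 to compound 4 (0.68 log units; beyond the scatter), so this change loses the only measurable growth inhibition seen so far. Of the four anilino rings shown, only the 4-chloro-2,5-dimethoxyphenyl ring of compound 3 gives a real number, and keeping one methoxy in compound 4 does not preserve it. The steps among compound 1, compound 2 and compound 4 cannot be read, because all three stop at the same limit: the limit of > 30000 nM in this assay, at which 3 of the 4 values shown sit.

Going by these compounds alone, what remains open is whether the chlorine or the two methoxy groups of compound 3 matter more, since no compound here changes only one of them. Also open, going by these compounds, is how an amine or a carboxylic acid on the anilino ring would shift the number.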